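Piperazine Aryl Swap in a Benzamide Series

The compounds below may be only part of what the source reports. "The series", "measured", "known", "first", "only" and "open" are said of these compounds alone.

Measured so far:
compound 1, `Nc1ccccc1NC(=O)c1ccc(CSC(=S)N2CCN(c3ccccc3)CC2)cc1`, 62.2%
compound 2, `Nc1ccccc1NC(=O)c1ccc(CSC(=S)N2CCN(c3cccnc3)CC2)cc1`, 66.2%
compound 3, `Nc1ccccc1NC(=O)c1ccc(CSC(=S)N2CCN(c3ncccn3)CC2)cc1`, 52.2%

All three were tested in a functional assay on HeLa cells (Homo sapiens) for antiproliferative activity, read by CCK-8 assay, with a stated time of 72 h, tested at 2 uM; on this read-out higher numbers stand for a stronger effect at the one concentration tested and lower numbers for a weaker effect. Compound 3 sits at the low end of the three numbers: the step from compound 1 is a number 10 percentage points lower from compound 1 to compound 3 (within the scatter), and the step from compound 2 is a number 14 percentage points lower from compound 2 to compound 3 (beyond the scatter). Compound 4, `Nc1ccccc1NC(=O)c1ccc(CSC(=S)N2CCN(Cc3cccnc3)CC2)cc1`, differs from compound 3 by (pyridin-3-yl)methyl in place of pyrimidin-2-yl on an amine nitrogen in a ring. The step that bears on this is a number 14 percentage points lower from compound 2 to compound 3 (beyond the scatter), since compound 2 already carries a pyridin-3-yl on the same ring nitrogen; a number 4 percentage points higher from compound 1 to compound 2 (within the scatter) shows the two six-membered aryl groups of compounds 1 and 2 sit close together. A modest rise is therefore expected for compound 4, a number 7.8 percentage points higher from compound 3 to compound 4 (within the scatter), in this assay. The estimate for compound 4 is 60%, with a range from 45% to 75%.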

Compound 4, a percentage reported as inhibition, at one concentration (the size of the read-out at that concentration, not a potency): 69.7%
For compound 4 the middle estimate is 9.7 percentage points below the measured one; the measured number falls inside the stated range.
By their numbers in this assay, from the lowest: compounds 3, 1, 2 and 4 (each within the scatter of the next, the first and the last beyond it).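

In this assay, (pyridin-3-yl)methyl on the amine nitrogen in the ring gives a number 17.5 percentage points higher from compound 3 to compound 4 (beyond the scatter), so this position allows a group carried on a methyl and not only an aryl group attached directly. The same group stays level with both directly attached aryl groups, with a number 3.5 percentage points higher from compound 2 to compound 4 (within the scatter) and a number 7.5 percentage points higher from compound 1 to compound 4 (within the scatter). Nothing available explains these steps.

As far as these compounds go, whether benzyl or a longer chain such as (pyridin-3-yl)ethyl would stay level with compound 4 remains open. So does whether the pyrimidine ring on a methyl would match compound 4.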